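The compounds below may be only part of what the source reports. "The series", "measured", "known", "first", "only" and "open" are said of these compounds alone.

Going by the values given here, compound 2, `Cc1n[nH]c2ccc(-c3nc4cnc(N5CCN(C)CC5)cn4c3Nc3ccc(F)c(Cl)c3)cc12`, holds the lower of the two numbers measured so far in a functional assay on CWR22R cells (Homo sapiens) for inhibition, with a stated time of 120 h, tested at 10 uM; on this read-out lower numbers stand for less inhibition and higher numbers for more inhibition at the one concentration tested (going by the name of the read-out): compound 2 gives 0.82%. Its nearest neighbour is compound 1, `Cc1n[nH]c2ccc(-c3nc4cnc(N5CCN(C)CC5)cn4c3Nc3ccc(Cl)cc3)cc12`, which in this assay gives 8.11%. The only measured step between these two, a number 7.3 percentage points lower from compound 1 to compound 2 (within the scatter), lies within the scatter, so on the numbers shown compound 2 and compound 1 cannot be told apart.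

Compound 3, `Cc1n[nH]c2ccc(-c3nc4cnc(N5CCN(C)CC5)cn4c3Nc3ccc(Cl)cc3Cl)cc12`, differs from compound 2 in one place: 2,4-dichlorophenyl in place of 3-chloro-4-fluorophenyl on a nitrogen on an aromatic ring. Among the compounds with values here, the one measured step that bears on this change is the one from compound 1 to compound 2, which also swapped the halogen pattern on the phenyl attached to that nitrogen, and it stayed within the scatter. Within the data shown here, with only that step to go on, no movement beyond the scatter is expected for this assay on moving to compound 3; the step of a number 3.2 percentage points higher from compound 2 to compound 3 (within the scatter) is therefore estimated as one that cannot be separated from repeat-measurement noise. For compound 3 the expected read-out in this assay is 4%, within a range from -10% to 20%.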

Compound 3, a percentage reported as inhibition, at one concentration (the size of the read-out at that concentration, not a potency): 9.53%
Compound 3: the middle estimate sits 5.5 percentage points below what was measured, and the stated range covers the measured number.
By their numbers in this assay, from the lowest: compounds 2, 1 and 3 (each within the scatter of the next).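

In this assay, the new result gives two further steps at the nitrogen on an aromatic ring: a number 8.7 percentage points higher from compound 2 to compound 3 (within the scatter), and a number 1.4 percentage points higher from compound 1 to compound 3 (within the scatter). The second is a single change, chloro in place of hydrogen on an aromatic carbon, which turns 4-chlorophenyl into 2,4-dichlorophenyl, and so it adds a one-atom comparison to the earlier swap of halogen patterns; with it, 4-chlorophenyl, 3-chloro-4-fluorophenyl and 2,4-dichlorophenyl on this nitrogen all stand within the scatter of one another, and this read-out does not tell the three apart. Nothing given here offers any account of these numbers.

Going by these compounds, all three compounds carry a halogenated phenyl on this nitrogen, so it remains open whether any other group there would give a step beyond the scatter, such as a methoxy group, a nitrile or a carboxylic acid on the phenyl, or a cyclohexyl ring in its place. Also open, on these data alone, is how these compounds would read at any concentration other than the single one tested.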